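Three weak analogues and a fourth still to be measured

The source may report more compounds than this note shows. Statements on the series, on what has been measured and on what is new or still open speak of the compounds shown alone.

Compound 2 `C=C1C[C@]23C[C@@]1(O)CC[C@H]2c1cc(Br)c(O)c(C)c1[C@@H]3Cn1cc(-c2ccc(F)cc2)nn1` is the only one of the three measured compounds to give a number in a functional assay on MCF7 cells (Homo sapiens) for cytotoxicity, read by MTT assay, with a stated time of 4 days (a lower number here means a stronger inhibitor, a higher number a weaker inhibitor), where compound 2 gives 19200 nM. Compound 1 `C=C1C[C@]23C[C@@]1(O)CC[C@H]2c1cc(Br)c(O)c(C)c1[C@@H]3Cn1cc(-c2ccc(OC)cc2)nn1` differs from compound 2 only by methoxy in place of fluoro on an aromatic carbon. In this assay compound 1 gives > 20000 nM, which is a limit of the assay rather than a number. That change made an at least 1.0-fold higher number from compound 2 to compound 1 (0.01 log units; that floor lies within the scatter). Compound 3 `C=C1C[C@]23C[C@@]1(O)CC[C@H]2c1ccc(O)c(C)c1[C@@H]3Cn1cc(-c2ccc(F)cc2)nn1` differs from compound 2 in its core by hydrogen in place of bromo on an aromatic carbon. In this assay compound 3 gives > 20000 nM, again a limit of the assay and not a number. That step reads an at least 1.0-fold higher number from compound 2 to compound 3 (0.01 log units; that floor lies within the scatter). Compound 4 `C=C1C[C@]23C[C@@]1(O)CC[C@H]2c1ccc(O)c(C)c1[C@@H]3Cn1cc(-c2ccc(OC)cc2)nn1` is not yet measured; it differs from compound 3 by methoxy in place of fluoro on an aromatic carbon, the same change as from compound 2 to compound 1, now set on the core that carries hydrogen in place of bromo. Because the limit of > 20000 nM in this assay, at which 2 of the 3 values shown sit, shows where most of these values sit, compound 4 is expected to show a step that the limit leaves unreadable from compound 3 to compound 4. The estimate for compound 4 is therefore 25000 nM, between 15000 nM and 60000 nM, and is expected to come back as a limit.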

Compound 4, half-maximal inhibitory concentration: > 20000 nM
Compound 4 was reported as a limit; the forecaster's own chance of this, stated with the estimate: 85%; the middle value is on the limit's open side.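

In this assay compound 4 gives > 20000 nM, a limit of the assay and not a number. Neither the step from compound 3 to compound 4 nor the step from compound 1 to compound 4 can be read, because all three compounds sit at the same limit: the limit of > 20000 nM in this assay, at which 3 of the 4 values shown sit.

As far as these compounds go, how strongly compound 1, compound 3 and compound 4 act on these cells, and whether methoxy in place of fluoro changes that on either core, stays open.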